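Fluorine on the Benzyl Amide of a T-Type Channel Blocker

The source may hold more compounds than are shown below. What is called first, only, known or untested is meant among the compounds shown, and "the series" means these compounds.

Of the compounds shown here, three have been measured in an assay on cells for inhibition of Voltage-dependent T-type calcium channel subunit alpha-1H (Homo sapiens), read by patch clamp; a higher number here means a weaker inhibitor, a lower number a stronger inhibitor. Compound 1, `O=C(CC1c2ccccc2N=C(SCCCCCN2CCCC2)N1c1ccc(-c2ccccc2)cc1)NCc1ccc(F)cc1`, gives 276000 nM. Compound 3, `O=C(CC1c2ccccc2N=C(SCCCCCN2CCCC2)N1c1ccc(-c2ccc(F)cc2)cc1)NCc1ccc(F)cc1`, gives 4880 nM. Compound 2, `CN(C)CCCCCSC1=Nc2ccccc2C(CC(=O)NCc2ccccc2)N1c1ccc(-c2ccccc2)cc1`, gives 2400 nM, the lowest of the three numbers. How compound 2 differs from compound 1 is not broken down here; the two cores differ in more than one place.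

From compound 1 to compound 3 the change is fluoro in place of hydrogen on an aromatic carbon, and it made the step of a 57-fold lower number from compound 1 to compound 3 (1.75 log units; beyond the scatter). Compound 4, `CN(C)CCCCCSC1=Nc2ccccc2C(CC(=O)NCc2ccc(F)cc2)N1c1ccc(-c2ccccc2)cc1`, is not yet measured. It differs from compound 2 by fluoro in place of hydrogen on an aromatic carbon, the same change, though cut one bond further out it reads benzyl to 4-fluorobenzyl rather than only phenyl to 4-fluorophenyl.

Because the earlier step of a 57-fold lower number from compound 1 to compound 3 (1.75 log units; beyond the scatter) was large but came from a different part of the shared core, and because compound 2 already sits at 2400 nM, the step expected here is smaller: a 1.6-fold lower number from compound 2 to compound 4 (0.20 log units; within the scatter). Compound 4 is therefore estimated at 1500 nM, between 500 nM and 5000 nM.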

Compound 4, half-maximal inhibitory concentration: 3140 nM
Compound 4: the middle estimate sits 2.1-fold (0.32 log units) below what was measured; the range from low to high includes it.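

The same swap of hydrogen for fluoro behaved very differently on the two cores in this assay: the same change on two cores in this assay, a 57-fold lower number (1.75 log units; beyond the scatter) from compound 1 to compound 3 and a 1.3-fold higher number (0.12 log units; within the scatter) from compound 2 to compound 4, 74-fold (1.87 log units) apart, beyond the scatter of two such steps

On the benzyl amide, the change gives a 1.3-fold higher number from compound 2 to compound 4 (0.12 log units; within the scatter), so it has no effect that can be told from repeat noise, whereas replacing pyrrolidin-1-yl with dimethylamino at the end of the chain gives an 88-fold lower number from compound 1 to compound 4 (1.94 log units; beyond the scatter). This does not show why the two fluoro steps part ways, since the pairs differ both in the amine on the chain and in which aromatic ring takes the fluoro, and the gap cannot be assigned to either difference.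

Still open, on these data alone, is what fluoro on the outer phenyl ring would do in the dimethylamino series, which would separate those two differences. Also open, as far as these compounds go, is how other ends to the chain, such as a piperidine or a morpholine, or chloro in place of fluoro, would fare.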